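The source may report more compounds than this note shows. Statements on the series, on what has been measured and on what is new or still open speak of the compounds shown alone.

In a functional assay on MIA PaCa-2 cells (Homo sapiens) for antiproliferative activity, read by sulforhodamine B assay, with a stated time of 48 h (a lower number here means a stronger inhibitor of growth, a higher number a weaker inhibitor of growth), compound 2 `O=C(NCc1cn(Cc2ccc(C(F)(F)F)cc2)nn1)c1cn(-c2ccccc2)nc1-c1ccc(Cl)cc1` gives 1100 nM, and this is the single numerical result on record, so it stands alone rather than among a ranked set. Compound 1 `COc1ccc(Cn2cc(CNC(=O)c3cn(-c4ccccc4)nc3-c3ccc(F)cc3)nn2)cc1OC` is a separate case: in this assay compound 1 reaches only > 100000 nM, which is a limit of the measurement and not a number. Compound 3 `COc1ccc(Cn2cc(CNC(=O)c3cn(-c4ccccc4)nc3-c3ccc(Cl)cc3)nn2)cc1OC` has not yet been measured. It differs from compound 2 in one place: 3,4-dimethoxyphenyl in place of 4-(trifluoromethyl)phenyl on a saturated chain carbon bound to an aromatic nitrogen. Compound 1 carries that same 3,4-dimethoxybenzyl group and sits at the limit, so a weakening relative to compound 2 is expected rather than a gain. The change is expected to cost a 27-fold higher number from compound 2 to compound 3 (1.44 log units; beyond the scatter), a loss well beyond the usual scatter of repeat measurements. Compound 3 is therefore estimated at 30000 nM, with a likely range from 5000 nM to 100000 nM, and a real chance that only a limit is reported.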

Compound 3, concentration for 50% growth inhibition: 9400 nM
Compound 3: the middle estimate sits 3.2-fold (0.50 log units) above what was measured; low and high end bracket the measured number.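

On the saturated chain carbon bound to an aromatic nitrogen, 3,4-dimethoxyphenyl in place of 4-(trifluoromethyl)phenyl gives an 8.5-fold higher number from compound 2 to compound 3 (0.93 log units; beyond the scatter) in this assay, so this position clearly affects growth inhibition, yet the 3,4-dimethoxybenzyl group still leaves a measurable number. With that group kept, chloro in place of fluoro on an aromatic carbon gives an at least 10-fold lower number from compound 1 to compound 3 (1.02 log units; beyond the scatter). The true size of this step stays unknown because compound 1 stands at a limit of the assay, not at a number: the limit of > 100000 nM in this assay, at which 1 of the 3 values shown sits.

Going by these compounds, whether chloro in place of fluoro matters as much alongside the 4-(trifluoromethyl)benzyl group remains open. Also open, on these data alone, is how a benzyl group carrying an amine or a carboxylic acid would behave at this position.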